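Ethoxycarbonyl in Place of Dioxolanyl: What to Expect Next

This account rests on a few compounds, and the source may have more. Where it says the series, first, only, none or still open, it means among the compounds named here.

Compound 1 `CCOC(=O)Cn1cc(C(O)c2ccc3ccccc3c2)nn1` is measured in a functional assay on B16 cells (Mus musculus) for cytotoxicity, read by MTT assay, with a stated time of 48 h; on this read-out higher numbers stand for weaker inhibition and lower numbers for stronger inhibition. The value for compound 1 is > 100000 nM, which is a limit of the assay and not a number.
Compound 2 `CC1(C)OCC(Cn2cc(C(O)c3ccc4ccccc4c3)nn2)O1` gives 26900 nM in this assay.
Compound 3 `CC1(C)OCC(Cn2cc(-c3ccc([N+](=O)[O-])cc3)nn2)O1` is also measured in this assay. The value for compound 3 is > 100000 nM, again a limit rather than a number.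

Compound 4 `CCOC(=O)Cn1cc(-c2ccc([N+](=O)[O-])cc2)nn1` has not yet been measured. Compared with compound 3 it carries one change: ethoxycarbonyl in place of 2,2-dimethyl-1,3-dioxolan-4-yl on a saturated chain carbon bound to an aromatic nitrogen. The very same change, at the same place, is already seen once in measured compounds, from compound 2 to compound 1: ethoxycarbonyl in place of 2,2-dimethyl-1,3-dioxolan-4-yl on a saturated chain carbon bound to an aromatic nitrogen. There it produced an at least 3.7-fold higher number from compound 2 to compound 1 (0.57 log units; beyond the scatter). The difference between the core of compound 2 and the core of compound 3 is not broken down here.

A newcomer should note what the measured step can and cannot say. Compound 1 sits at the limit of > 100000 nM in this assay, at which 2 of the 3 values shown sit, so the step is known only as a lower bound. Compound 3 also already sits at that limit, which leaves no room for the change to show a further rise in the number.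

On that basis the expected step in this assay is a step that the limit leaves unreadable from compound 3 to compound 4, resting on the earlier step of an at least 3.7-fold higher number from compound 2 to compound 1 (0.57 log units; beyond the scatter) and on the limit of compound 3. Compound 4 is therefore estimated at 200000 nM, and most likely the assay will report only a limit again, with the plausible range running from 100000 nM to 1000000 nM.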

Compound 4, half-maximal inhibitory concentration: > 100000 nM
Compound 4 ended at the assay's limit (the forecaster's own chance of this, stated with the estimate: 90%); the middle value does not contradict the limit.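

No step can be read from compound 3 to compound 4, because both end at a limit of this assay and neither gives a number: the limit of > 100000 nM in this assay, at which 3 of the 4 values shown sit.

The compounds shown leave open whether ethoxycarbonyl in place of 2,2-dimethyl-1,3-dioxolan-4-yl changes the number at all on the core of compound 3, and so whether the step seen on the core of compound 2 carries over to it.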